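This account rests on a few compounds, and the source may have more. Where it says the series, first, only, none or still open, it means among the compounds named here.

Three compounds share one core and differ only in the amine attached to it. Compound 1 `Cc1nc(N2CCCCC2)c2nnn(-c3ccc(C(C)C)cc3Br)c2n1` carries a piperidin-1-yl group, and in an in vitro assay on 293-EBNA cells for binding affinity to corticotropin-releasing factor receptor 1 (Homo sapiens) (on this read-out lower numbers stand for stronger inhibition and higher numbers for weaker inhibition), compound 1 gives 46 nM. Compound 2 `COCC(COC)Nc1nc(C)nc2c1nnn2-c1ccc(C(C)C)cc1Br` carries a (2-methoxy-1-(methoxymethyl)ethyl)amino group in its place; in this assay compound 2 gives 10.3 nM, and the step is a 4.5-fold lower number from compound 1 to compound 2 (0.65 log units; beyond the scatter). Compound 3 `COCC(COC)N(C)c1nc(C)nc2c1nnn2-c1ccc(C(C)C)cc1Br` adds a methyl on that amine nitrogen; in this assay compound 3 gives 21.3 nM. Compound 3 thus holds the second highest of the three numbers: the step of a 2.2-fold lower number from compound 1 to compound 3 (0.33 log units; beyond the scatter), while the step of a 2.1-fold higher number from compound 2 to compound 3 (0.32 log units; beyond the scatter).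

Compound 4 `COCC(C)(C)Nc1nc(C)nc2c1nnn2-c1ccc(C(C)C)cc1Br` has not yet been measured. It differs from compound 3 in a group of 7 heavy atoms (5 carbon, 1 nitrogen, 1 oxygen; no ring) in place of a group of 9 heavy atoms (6 carbon, 1 nitrogen, 2 oxygen; no ring), on an aromatic carbon; the group that enters has 1 hydrogen-bond donor and 2 hydrogen-bond acceptors, the one that leaves 0 hydrogen-bond donors and 3 hydrogen-bond acceptors. Among the measured compounds shown here, one measured step bears directly on this: a 2.1-fold higher number from compound 2 to compound 3 (0.32 log units; beyond the scatter) shows that a methyl on the amine nitrogen raised the number, and compound 4 returns a hydrogen there. For the measured compounds named here, no measured step shows what replacing one methoxymethyl by methyl does. A modest lowering is therefore expected: a 1.8-fold lower number from compound 3 to compound 4 (0.25 log units; within the scatter). For compound 4 the estimate in this assay is 12 nM, with a range from 5 nM to 30 nM.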

Compound 4, inhibition constant: 195 nM
The estimate for compound 4 lay 16-fold (1.21 log units) below the measured number; measured number outside the range, above it.
By their numbers in this assay, from the lowest: compound 2; then compound 3; then compound 1; then compound 4.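

Side-chain shape on this amine matters more than the earlier compounds suggested. With the hydrogen on the amine nitrogen kept, replacing 2-methoxy-1-(methoxymethyl)ethyl by 1-(methoxymethyl)-1-methylethyl in this assay gives a 19-fold higher number from compound 2 to compound 4 (1.28 log units; beyond the scatter), a larger change than adding the methyl on that nitrogen, which gave a 2.1-fold higher number from compound 2 to compound 3 (0.32 log units; beyond the scatter). A hydrogen on the nitrogen therefore does not guarantee a low number: the swap gives a 9.2-fold higher number from compound 3 to compound 4 (0.96 log units; beyond the scatter), and the piperidin-1-yl group also compares favourably, with a 4.2-fold higher number from compound 1 to compound 4 (0.63 log units; beyond the scatter), although compound 2 lies on the other side of compound 1. The data shown offer no measurement that explains this loss.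

The step from compound 2 to compound 4 changes the carbon attached to the nitrogen in more than one way, so it cannot say whether losing a methoxymethyl or gaining the extra methyl matters more. A (2-methoxy-1-methylethyl)amino group would help to separate the two, while a (1,3-diethoxypropan-2-yl)amino group would test whether the two-armed chain tolerates longer ends.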